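Replacing the Aryl Arm with a Methyl Group

The source may hold more compounds than are shown below. What is called first, only, known or untested is meant among the compounds shown, and "the series" means these compounds.

Of the compounds shown here, two built on one shared core have been measured in a functional assay, read by spectrophotometry, with a stated time of 15 min; on this read-out lower numbers stand for stronger inhibition and higher numbers for weaker inhibition. Compound 1 `Cc1nc2c3ccccc3ccc2c2nc3c(ccc4ccccc43)c(-c3cc([N+](=O)[O-])ccc3N)c12` gives 43.3 ug/mL. Compound 2 `Cc1nc2c3ccccc3ccc2c2nc3c(ccc4ccccc43)c(-c3ccc(O)cc3)c12` gives, in this assay, 44.1 ug/mL. Among the measured compounds shown here, the single step between them, a 1.0-fold higher number from compound 1 to compound 2 (0.01 log units; within the scatter), shows that exchanging one aromatic arm for another left the read-out where it was, so compound 2 stands alongside compound 1 with no meaningful gap between the two.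

Compound 3 `Cc1nc2c3ccccc3ccc2c2nc3c(ccc4ccccc43)c(C)c12` differs from compound 2 by methyl in place of 4-hydroxyphenyl on an aromatic carbon, removing the ring altogether. For the measured compounds named here, no measured step covers a change of this kind; the only step available, a 1.0-fold higher number from compound 1 to compound 2 (0.01 log units; within the scatter), swaps one ring for another and lies within the scatter. On that slender footing, a step of a 1.1-fold higher number from compound 2 to compound 3 (0.05 log units; within the scatter) in this assay is expected, with wide uncertainty. Compound 3 is therefore estimated at 50 ug/mL, within a range from 20 ug/mL to 150 ug/mL.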

Compound 3, half-maximal inhibitory concentration: 89.6 ug/mL
The estimate for compound 3 lay 1.8-fold (0.25 log units) below the measured number; measured number inside the range.
By their numbers in this assay, from the lowest: compounds 1 and 2 (each within the scatter of the next); then compound 3.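

In this assay, this position proves sensitive to a change that the swap of one aromatic arm for another could not reveal. Methyl in place of 4-hydroxyphenyl gives a 2.0-fold higher number from compound 2 to compound 3 (0.31 log units; beyond the scatter), and methyl in place of 2-amino-5-nitrophenyl gives a 2.1-fold higher number from compound 1 to compound 3 (0.32 log units; beyond the scatter), so inhibition weakens modestly, but beyond the scatter, whichever of the two rings is removed. Nothing available explains this weakening.

The compounds shown leave open whether an aromatic ring is needed here at all, since a plain phenyl, a cyclohexyl ring and a longer chain such as butyl all lie between these arms and methyl. They also leave open how an amine or a carboxylic acid placed directly on this aromatic carbon would compare.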